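Piperidinylcarbonyl in place of the charged group: compound 4

A few compounds are considered here, and "the series" means these few. Any claim that something is new, unique, unknown or untested is made for them only; others in the source may bear on it.

Within the shared core of compound 2 `COc1ccc(-c2nc(/N=C(\N)[N+]3(C)CCCCC3)sc2-c2ccc(OC)cc2)cc1`, three compounds have been tested in a functional assay (aorta) with Rattus norvegicus as the target; a lower number here means that less compound is needed, a higher number that more compound is needed for the effect. Going by the values given here, compound 2 is the only one with a number: in this assay compound 2 gives 21 uM. Compound 1 `COc1ccc(-c2nc(/N=C(\N)NC3CCCCC3)sc2-c2ccc(OC)cc2)cc1` returns only a limit, > 100 uM. Compound 3 `COc1ccc(-c2nc(C(=O)N3CCOCC3)sc2-c2ccc(OC)cc2)cc1` likewise returns only a limit, < 100 uM. Among the compounds with values here, the one readable step is an at least 4.7-fold lower number from compound 1 to compound 2 (0.67 log units; beyond the scatter); the others, a step that the limit leaves unreadable from compound 2 to compound 3 and a number no higher from compound 1 to compound 3 (the limit leaves the size open), give no size.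

Compound 4 `COc1ccc(-c2nc(C(=O)N3CCCCC3)sc2-c2ccc(OC)cc2)cc1` is the next candidate. The change: a group of 8 heavy atoms (6 carbon, 1 nitrogen, 1 oxygen; one six-membered non-aromatic ring with 1 hetero atom) in place of a group of 10 heavy atoms (7 carbon, 3 nitrogen; one six-membered non-aromatic ring with 1 hetero atom), on an aromatic carbon. Of the measured steps, a step that the limit leaves unreadable from compound 2 to compound 3 is the closest parallel, as compound 3 also carries a carbonyl-bound six-membered ring with a hetero atom on an aromatic carbon; it yields no size and no direction. The step of an at least 4.7-fold lower number from compound 1 to compound 2 (0.67 log units; beyond the scatter) shows that substitution at this carbon can move the read-out markedly, though that change introduced the net charge which compound 4 removes. With no readable direction, the expectation sits near compound 2 with a wide range. Compound 4 is expected at 40 uM, between 10 uM and 150 uM, corresponding to an expected step of a 1.9-fold higher number from compound 2 to compound 4 (0.28 log units; within the scatter).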

Compound 4, concentration for half-maximal effect: 11 uM
Beside the measured number, compound 4's estimate is 3.6-fold (0.56 log units) above it; low and high end bracket the measured number.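

In this assay the step of a 1.9-fold lower number from compound 2 to compound 4 (0.28 log units; within the scatter) shows that, on this aromatic carbon of the five-membered ring, the group with net charge +1 can be replaced by (piperidin-1-yl)carbonyl, with no net charge and no hydrogen-bond donor, without a difference that can be told apart from the scatter. A net charge is therefore not required for a measured number in the shared core, at least for this pair. The step of an at least 9.0-fold lower number from compound 1 to compound 4 (0.95 log units; beyond the scatter) lies beyond the scatter, and compound 1 gives > 100 uM as a limit of the assay and not as a number, so this step has a minimum size and no exact one.

The step with compound 3 cannot be read, so piperidin-1-yl against morpholin-4-yl on the carbonyl carbon stays without a size, and the compounds shown say nothing about a carboxylic acid, an open-chain amine or a longer chain on this aromatic carbon. No measurement shown here gives a reason for the result.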